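The source may report more compounds than this note shows. Statements on the series, on what has been measured and on what is new or still open speak of the compounds shown alone.

Within the data shown here, in a functional assay on HeLa cells (Homo sapiens) for antiproliferative activity, read by MTT assay, with a stated time of 48 h (a higher number here means a weaker inhibitor of growth, a lower number a stronger inhibitor of growth), compound 1 (`COc1cc(C2C(C#N)=C(N)Oc3cc(N(C)C)ccc32)cc(OC)c1OC`) gives (17 nM), the lowest number so far and beyond the scatter from the nearest value. That nearest value belongs to compound 2 (`Cc1cc2c(c(=O)n1C)C(c1ccc(F)c(Br)c1)C(C#N)=C(N)O2`), at (6400 nM). Compound 3 (`Cc1cc2c(c(=O)o1)C(c1cccc(Br)c1)C(C#N)=C(N)O2`) reads (> 100000 nM), which is a limit and not a number. Compound 4 (`COc1cc(C2C(C#N)=C(N)Oc3cc(N(C)C)ccc32)cc(Br)c1OC`) has bromo in place of methoxy on an aromatic carbon, ortho to a methoxy group and meta to a large group (bromo in place of methoxy on an aromatic carbon). Among the measured compounds shown here, compounds 2 and 3 also carry bromo, but on a different core, and no measured step isolates this swap. The expected step (a 1.2-fold lower number from compound 1 to compound 4 (0.08 log units; within the scatter)) is estimated to stay within the scatter, with no firm direction. In this assay, the estimate for compound 4 is (14 nM), with an expected range from 3 nM to 70 nM (estimated).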

Compound 4, concentration for 50% growth inhibition: 7 nM
The estimate for compound 4 lay 2.0-fold (0.30 log units) above the measured number; measured number inside the range.
By their numbers in this assay, from the lowest: compound 4; then compound 1; then compound 2. At a limit, above all of these: compound 3.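

The swap of bromo in place of methoxy gives a 2.4-fold lower number from compound 1 to compound 4 (0.39 log units; beyond the scatter) in this assay on this aromatic carbon, ortho to a methoxy group and meta to a large group. Among these compounds, it is the first single change measured, and it shows that this methoxy group can leave the core of compound 1 without any loss of growth inhibition. Nothing shown bears on what lies behind the step.

On these data alone, whether chloro, hydroxy or an amine on this carbon would read like bromo stays open. So does the effect of a longer alkoxy chain here.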